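The source may hold more compounds than are shown below. What is called first, only, known or untested is meant among the compounds shown, and "the series" means these compounds.

Measured so far:
- compound 1, `Cc1ccc(-c2ccnc(Nc3cccc(N(C)C)c3)n2)s1`: 5700 nM
- compound 2, `Fc1ccc(Nc2nccc(-c3ccncc3)n2)cc1`: 1900 nM
- compound 3, `CC1CCN(c2ccc(Nc3nccc(-c4cccs4)n3)cc2)CC1`: 400 nM

These three compounds share a core and were tested in a functional assay for inhibition, with Homo sapiens as the target; a higher number here means a weaker inhibitor, a lower number a stronger inhibitor. Among them, compound 1 gives the highest number, so it is the weakest inhibitor of the three; compound 2 sits nearer to it and compound 3 furthest away, and both gaps are beyond the usual scatter.

Compound 4, `CN(C)c1cccc(Nc2nccc(-c3ccncc3)n2)c1`, has not yet been measured in this assay. It differs from compound 1 in one place: pyridin-4-yl in place of 5-methylthiophen-2-yl on an aromatic carbon. For the measured compounds named here, no measured pair here shows this exact change on its own, so the size of the step is open. Compound 2, which carries the pyridin-4-yl group, gives 1900 nM in this assay, a stronger result than compound 1, which hints that this group is tolerated. The step is expected to be modest and towards a lower number, a 1.6-fold lower number from compound 1 to compound 4 (0.21 log units; within the scatter). Compound 4 is therefore estimated at 3500 nM, with a range from 1200 nM to 10000 nM.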

Compound 4, half-maximal inhibitory concentration: 3700 nM
The estimate for compound 4 lay 1.1-fold (0.02 log units) below the measured number; the range from low to high includes it.
By their numbers in this assay, from the lowest: compound 3; then compounds 2, 4 and 1 (each within the scatter of the next, the first and the last beyond it).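

In this assay, putting pyridin-4-yl in place of 5-methylthiophen-2-yl on this aromatic carbon gives a 1.5-fold lower number from compound 1 to compound 4 (0.19 log units; within the scatter) and leaves the rest of the molecule unchanged. For the compounds shown here, this pair is the first direct test of the change. The earlier compounds shown here differed in more than one place and could only hint at it. It shows that, with this partner, a six-membered aromatic ring with one nitrogen and a five-membered aromatic ring with one sulfur cannot be told apart in this assay. Nothing measured here explains why the two groups read alike.

Going by these compounds, whether a plain phenyl ring or a carboxylic acid on the same carbon would separate from these two groups remains open. This single pair also cannot say whether the change would read the same with the other groups seen in compound 2 or compound 3.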